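Chloro for Cyclopropyl: What to Expect of Compound 4

A few compounds are considered here, and "the series" means these few. Any claim that something is new, unique, unknown or untested is made for them only; others in the source may bear on it.

Compound 1 `Cn1nc(CN2CCCC2)nc1-c1ccc(C2CC2)cc1` gives 1000 nM in an assay on membranes from Jurkat cells for displacement of a labelled ligand from Sigma intracellular receptor 2 (Homo sapiens), read by scintillation counting, with a stated time of 1 h; on this read-out higher numbers stand for weaker inhibition and lower numbers for stronger inhibition.
Compound 2 `Cn1nc(CN2CCCC2)nc1-c1ccc2c(c1)CCCC2` gives > 1000 nM in this assay, which is a limit of the assay and not a number.
Compound 3 `Cn1nc(CN2CCCC2)nc1-c1ccc2ccsc2c1` gives > 1000 nM in this assay, again a limit rather than a number.

Going by the values given here, compound 1 therefore holds the only real number among the three measured compounds, while the other two sit at the limit of > 1000 nM in this assay, at which 2 of the 3 values shown sit. Compound 4 `Cn1nc(CN2CCCC2)nc1-c1ccc(Cl)cc1` has not been measured. It differs from compound 1 in one place: chloro in place of cyclopropyl on an aromatic carbon. Among the compounds with values here, no pair of measured compounds shows how a change of this kind moves binding, so no measured step can guide the expectation. The step of a 1.2-fold higher number from compound 1 to compound 4 (0.08 log units; within the scatter) is expected to stay within the usual scatter, in no clear direction. Compound 4 is expected to give 1200 nM, within a range from 400 nM to 4000 nM, with a fair chance that only a limit is reported.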

Compound 4, inhibition constant: > 1000 nM
Compound 4 gave a limit, no number; the forecaster's own chance of this, stated with the estimate: 45%; the middle value does not contradict the limit.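

Putting chloro in place of cyclopropyl on the aromatic carbon gives a number no lower from compound 1 to compound 4 (the limit leaves the size open). Going by these compounds alone, this is the first step seen at this position, and it shows no gain in binding, although its size cannot be read. Compound 1 remains the only compound with a real number, while the others stop at a limit of the assay: the limit of > 1000 nM in this assay, at which 3 of the 4 values shown sit.

As far as these compounds go, how far compound 2, compound 3 and compound 4 lie past that limit stays open. So does whether an amine or a carboxylic acid at this position would bind more strongly than compound 1.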